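The compounds below may be only part of what the source reports. "The series", "measured", "known", "first", "only" and "open" are said of these compounds alone.

Compound 1 `CN1CCC(c2ccc(Cl)cc2)C(C[S+]([O-])CCO)C1` gives 42 nM in an assay on isolated protein for inhibition of Norepinephrine transporter (Rattus norvegicus), read by radioligand binding; on this read-out higher numbers stand for weaker inhibition and lower numbers for stronger inhibition.
Compound 2 `COCC[S+]([O-])CC1CN(C)CCC1c1ccc(Cl)cc1` gives 25 nM in this assay.

Compound 2 shows the lower of the two numbers, but its gap to compound 1 lies within the scatter: a 1.7-fold lower number from compound 1 to compound 2 (0.23 log units; within the scatter). Compound 3 `CC(=O)OCCSCC1CN(C)CCC1c1ccc(Cl)cc1` differs from compound 2 by a group of 7 heavy atoms (4 carbon, 2 oxygen, 1 sulfur; no ring) in place of a group of 6 heavy atoms (3 carbon, 2 oxygen, 1 sulfur; no ring), on a saturated chain carbon bound to a saturated ring carbon. Among the measured compounds shown here, the only measured step, from compound 1 to compound 2, also alters the end of this side chain and stays within the scatter; nothing measured speaks to the change at the sulfur itself. Compound 3 is therefore expected to stay near compound 2, with a step of a 1.2-fold higher number from compound 2 to compound 3 (0.08 log units; within the scatter) in this assay. The estimate for compound 3 is 30 nM, between 8 nM and 120 nM.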

Compound 3, inhibition constant: 3.6 nM
For compound 3 the middle estimate is 8.3-fold (0.92 log units) above the measured one, and the stated range ends above it.
By their numbers in this assay, from the lowest: compound 3; then compounds 2 and 1 (each within the scatter of the next).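

At the saturated chain carbon bound to a saturated ring carbon, the side chain proves able to move the result in this assay: (2-acetoxyethyl)sulfanyl gives a step beyond the scatter against the group of compound 2 (a 6.9-fold lower number from compound 2 to compound 3 (0.84 log units; beyond the scatter)) and a large one against the group of compound 1 (a 12-fold lower number from compound 1 to compound 3 (1.07 log units; beyond the scatter)), whereas the earlier step at the chain end alone stayed within the scatter. This change alters the sulfur and the chain end together, so the step cannot be assigned to either part. Nothing on hand accounts for this difference.

The compounds shown leave open how much of the step would remain with a plain hydroxyl or methoxy end on the same sulfanyl chain. They also leave open what an amine, a carboxylic acid or a longer ester chain would give at this position.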